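Thiophene exchange on the shared core, compound 2 to compound 3

A few compounds are considered here, and "the series" means these few. Any claim that something is new, unique, unknown or untested is made for them only; others in the source may bear on it.

In a functional assay on cells (Cancer cell lines, Homo sapiens) for inhibition (on this read-out higher numbers stand for weaker inhibition of growth and lower numbers for stronger inhibition of growth), compound 1 (`N=C(N)N/N=C/c1c(-c2ccsc2)nc2sccn12`) gives 17400 nM and compound 2 (`N=C(N)N/N=C/c1c(-c2cccs2)nc2sccn12`) gives 14800 nM on the same read-out. These two numbers lie within the scatter of each other, so compound 2 cannot be separated from compound 1.

Compound 3 (`Cc1cc(-c2nc3sccn3c2/C=N/NC(=N)N)c(C)s1`) differs from compound 2 by 2,5-dimethylthiophen-3-yl in place of thiophen-2-yl on an aromatic carbon and thus has 2,5-dimethylthiophen-3-yl in place of thiophen-2-yl on an aromatic carbon.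

Going by the values given here, only one measured step bears on this change: a 1.2-fold lower number from compound 1 to compound 2 (0.07 log units; within the scatter) is small and concerns the thiophene attachment alone. Among the compounds with values here, no measured compound carries the methyl groups, so their contribution is untested. No step beyond the scatter is therefore expected, and the estimated step is a 1.2-fold lower number from compound 2 to compound 3 (0.09 log units; within the scatter) in this direction.

For compound 3 the expected value is 12000 nM with an expected range from 4000 nM to 35000 nM in this assay.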

Compound 3, concentration for 50% growth inhibition: 16200 nM
Estimate against measurement, compound 3: 1.4-fold (0.13 log units) below, and the stated range covers the measured number.
By their numbers in this assay, from the lowest: compounds 2, 3 and 1 (each within the scatter of the next).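

In this assay, 2,5-dimethylthiophen-3-yl in place of thiophen-2-yl gives a 1.1-fold higher number from compound 2 to compound 3 (0.04 log units; within the scatter) and in place of thiophen-3-yl gives a 1.1-fold lower number from compound 1 to compound 3 (0.03 log units; within the scatter) at this position, so neither exchange yields a step beyond the scatter. The earlier pair spoke only to how the thiophene is attached; compound 3 adds two methyl groups on that ring, and this too leaves the number inseparable from those of compound 1 and compound 2. No supporting data on the cause of this flat reading are available.

Going by these compounds, all three compounds carry a thiophene at this place, so the effect of a group such as an amine, a carboxylic acid or a longer alkyl chain here remains open. On these data alone, the group of 6 heavy atoms on the neighbouring ring atom stays the same throughout, and its contribution to growth inhibition also remains open.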